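A few compounds are considered here, and "the series" means these few. Any claim that something is new, unique, unknown or untested is made for them only; others in the source may bear on it.

Working notes on the series. Three compounds have been run in a physicochemical assay for lipophilicity, read by HPLC, measured as chromatographic lipophilicity, at pH 7.4; on this read-out higher numbers stand for higher lipophilicity and lower numbers for lower lipophilicity. Compound 1 `O=C(C1CCCCC1)N1CCC(C(=O)N2N=CCC2c2ccccc2)CC1` gives 5.4; compound 2 `O=C(C1CCN(C(=O)C(F)(F)F)CC1)N1N=CCC1c1ccccc1` gives 4.9; compound 3 `CC(C)(C)C(=O)N1N=CCC1c1cccc(Cl)c1` gives 6.6. On these numbers compound 2 stands lowest: compound 1 sits nearest, and compound 3 sits furthest away, both of them higher by more than the scatter. Among the compounds with values here, the one single-point step measured so far is a number 0.50 log units lower from compound 1 to compound 2 (beyond the scatter).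

The next compound, compound 4 `O=C(c1ccccc1)N1CCC(C(=O)N2N=CCC2c2ccccc2)CC1`, differs from compound 2 in one place: phenyl in place of trifluoromethyl on a carbonyl carbon. Within the data shown here, the change is the same as the measured step read backwards in kind, a trifluoromethyl giving way to a carbon ring on the same carbonyl carbon, though here the ring that enters is phenyl rather than cyclohexyl, so the step from compound 1 to compound 2 is the only direct guide, and it points upward. A rise in this assay is therefore expected for compound 4, of a size somewhat smaller than the drop seen on going from compound 1 to compound 2, and its estimated step is a number 0.30 log units higher from compound 2 to compound 4 (within the scatter). The estimate for compound 4 in this assay is 5.2, with a range from 4.7 to 5.7.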

Compound 4, distribution coefficient: 4.4
Compound 4: the middle estimate sits 0.80 log units above what was measured, outside the stated range (below it).
By their numbers in this assay, from the lowest: compound 4; then compound 2; then compound 1; then compound 3.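

In this assay, the carbonyl carbon now carries three different groups, and phenyl in place of trifluoromethyl gives a number 0.50 log units lower from compound 2 to compound 4 (beyond the scatter), while phenyl in place of cyclohexyl gives a number 1.00 log units lower from compound 1 to compound 4 (beyond the scatter). A ring entering at this carbon therefore does not by itself raise the number: the two rings, cyclohexyl and phenyl, stand on either side of trifluoromethyl, and the aromatic ring gives the lowest number of the three. Nothing available bears on the reason for this order.

As far as these compounds go, it remains open where a carboxylic acid, an amine or a longer alkyl chain on the same carbonyl carbon would fall relative to these three groups. From the compounds shown here alone, it is also open whether the same order holds on a different core.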